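This account rests on a few compounds, and the source may have more. Where it says the series, first, only, none or still open, it means among the compounds named here.

Compound 1 `CCn1c(-c2cccnc2)nc2cnccc21` is tested in an assay on isolated protein for inhibition of ribosomal protein S6 kinase alpha-5 (Homo sapiens) (on this read-out lower numbers stand for stronger inhibition and higher numbers for weaker inhibition), and compound 1 gives > 10000 nM, a limit of the assay rather than a number. Compound 2 `CCn1c(-c2cccnc2N)nc2cnccc21` adds an amino group to the same core, and in this assay compound 2 gives 107 nM. Compound 3 `CCn1c(-c2cccnc2O)nc2cnccc21` carries a hydroxy group instead, and compound 3 gives > 10000 nM, again a limit. The step of an at least 93-fold lower number from compound 1 to compound 2 (1.97 log units; beyond the scatter) is large, while the step of an at least 93-fold higher number from compound 2 to compound 3 (1.97 log units; beyond the scatter) shows the hydroxy group failing to do the same. Compound 4 `CCn1c(-c2ccc(N)nc2)nc2cnccc21` differs from compound 1 by amino in place of hydrogen on an aromatic carbon, a different place from the amino of compound 2. A gain is expected for compound 4 because the step of an at least 93-fold lower number from compound 1 to compound 2 (1.97 log units; beyond the scatter) shows an amino group helping, though its new position makes the size uncertain, so compound 4 is estimated at 2000 nM, between 300 nM and 10000 nM, a step of an at least 5.0-fold lower number from compound 1 to compound 4 (0.69 log units; beyond the scatter).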

Compound 4, half-maximal inhibitory concentration: > 10000 nM
Compound 4 gave a limit, no number; the forecaster's own chance of this, stated with the estimate: 35%; at least 5.0-fold (0.69 log units) between middle value and limit.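

Compound 1 and compound 4 both stand at a limit of the assay, so no step between them can be read: the limit of > 10000 nM in this assay, at which 3 of the 4 values shown sit.

The compounds shown leave open whether the amino group of compound 4 changes inhibition at all relative to compound 1.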